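This account rests on a few compounds, and the source may have more. Where it says the series, first, only, none or still open, it means among the compounds named here.

Measured in an ADME assay on DU-145 cells (Homo sapiens) for cytotoxicity, read by MTT assay, with a stated time of 72 h; a higher number here means a weaker inhibitor, a lower number a stronger inhibitor:

- compound 1 `COC(=O)c1cc(C2=C(c3cc(OC)c(OC)c(OC)c3)C(=O)CC2O[SiH2]C(C)(C)C)ccc1OC`: > 100 ug/mL
- compound 2 `COc1ccc(OC)c(C2=C(c3cc(OC)c(OC)c(OC)c3)C(=O)CC2O)c1`: > 100 ug/mL
- compound 3 `O/N=C1/CC(O)C(c2ccccc2)=C1c1ccccc1`: > 100 ug/mL

Compound 1 reads > 100 ug/mL in this assay, and this is a limit, not a number. It has company, since the data so far amount to the limit of > 100 ug/mL in this assay, at which 3 of the 3 values shown sit. Compound 4 `COc1ccc(C2=C(c3cc(OC)c(OC)c(OC)c3)C(=O)CC2O[SiH2]C(C)(C)C)cc1O` differs from compound 1 in one place: hydroxy in place of methoxycarbonyl on an aromatic carbon. Hydroxy takes the place of methoxycarbonyl on an aromatic carbon, ortho to a methoxy group. Among the measured compounds shown here, no measured pair gives a size for such a change, so what follows is a rough expectation. The expected at least 20-fold lower number from compound 1 to compound 4 (1.30 log units; beyond the scatter) points toward a stronger inhibitor, though a result at the limit remains quite possible. Compound 4 is estimated at 5 ug/mL, with an expected range from 0.05 ug/mL to 100 ug/mL.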

Compound 4, half-maximal inhibitory concentration: 75 ug/mL
The estimate for compound 4 lay 15-fold (1.18 log units) below the measured number; the measured number falls inside the stated range.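

In this assay compound 4, with hydroxy in place of methoxycarbonyl, gives 75 ug/mL, a measured number rather than a limit, unlike the others: the limit of > 100 ug/mL in this assay, at which 3 of the 4 values shown sit. Compound 1 reads > 100 ug/mL, which is a limit and not a number. As far as these compounds go, the change can therefore be stated only as a floor, an at least 1.3-fold lower number from compound 1 to compound 4 (0.12 log units; that floor lies within the scatter), so its true size remains unknown and may be small. From the compounds shown here alone, whether another group at this position, such as an amine or a carboxylic acid, would give a lower number remains open. So does whether hydroxy would have a similar effect on other cores.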